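The compounds below may be only part of what the source reports. "The series", "measured", "known", "first", "only" and "open" are said of these compounds alone.

The measured compounds in a functional assay on HT-29 cells (Homo sapiens) for inhibition, read by MTT assay, with a stated time of 48 h (on this read-out higher numbers stand for weaker inhibition and lower numbers for stronger inhibition), are:
compound 1, `Cc1ccc(NC(=S)NC(=O)c2ccc(OCc3ccc(C(F)(F)F)cc3)cc2)cc1-c1nc2ccccc2[nH]1`, which gives 17600 nM;
compound 2, `Cc1ccc(COc2ccc(C(=O)NC(=S)Nc3ccc(C)c(-c4nc5ccccc5[nH]4)c3)cc2)cc1`, which gives 14200 nM;
compound 3, `Cc1ccc(NC(=S)NC(=O)c2ccc(OCc3ccc(Cl)c(Cl)c3)cc2)cc1-c1nc2ccccc2[nH]1`, which gives 6270 nM.

Compound 3 stands at the lowest number of the three. The step of a 2.8-fold lower number from compound 1 to compound 3 (0.45 log units; beyond the scatter) and the step of a 2.3-fold lower number from compound 2 to compound 3 (0.36 log units; beyond the scatter) both set it apart from the other two, whereas the step of a 1.2-fold lower number from compound 1 to compound 2 (0.09 log units; within the scatter) leaves compounds 1 and 2 indistinguishable from one another.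

Compound 4, `Cc1ccc(NC(=S)NC(=O)c2ccc(OCc3ccc(Cl)cc3Cl)cc2)cc1-c1nc2ccccc2[nH]1`, has not yet been measured in this assay. It differs from compound 3 by 2,4-dichlorophenyl in place of 3,4-dichlorophenyl on a saturated chain carbon bound to an oxygen on an aromatic ring. The two structures hold the same atoms, joined differently, so this is a rearrangement of the same dichlorinated ring rather than an exchange of groups. Among the measured compounds shown here, none of the measured steps compares two arrangements of the same atoms; each swaps one group for another. For the measured compounds named here, the steps of a 2.8-fold lower number from compound 1 to compound 3 (0.45 log units; beyond the scatter) and a 2.3-fold lower number from compound 2 to compound 3 (0.36 log units; beyond the scatter) show only that a ring bearing two chlorines gave a modestly lower number than a ring bearing a single trifluoromethyl or methyl. Compound 4 keeps both chlorines, so no step beyond the scatter is expected in this assay. Compound 4 is therefore estimated at 7000 nM, with a range from 3000 nM to 16000 nM. The expected step of a 1.1-fold higher number from compound 3 to compound 4 (0.05 log units; within the scatter) is accordingly small and within the usual scatter.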

Compound 4, half-maximal inhibitory concentration: 11600 nM
For compound 4 the middle estimate is 1.7-fold (0.22 log units) below the measured one, and the stated range covers the measured number.
By their numbers in this assay, from the lowest: compounds 3, 4, 2 and 1 (each within the scatter of the next, the first and the last beyond it).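

In this assay, among the compounds shown here, this is the first comparison of two arrangements of the same atoms on the saturated chain carbon bound to an oxygen on an aromatic ring, and the 3,4-dichlorophenyl and 2,4-dichlorophenyl rings cannot be told apart (a 1.9-fold higher number from compound 3 to compound 4 (0.27 log units; within the scatter)). The new ring nevertheless does not share the separation that compound 3 showed from the rings with a single methyl or trifluoromethyl, since compound 4 stays within the scatter of both (a 1.2-fold lower number from compound 2 to compound 4 (0.09 log units; within the scatter); a 1.5-fold lower number from compound 1 to compound 4 (0.18 log units; within the scatter)), so carrying two chlorines does not by itself set a compound apart from those two. No measurement is available that would explain this result.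

The four compounds leave open whether a ring bearing a single chlorine, a methoxy group or an amine at this place would group with compound 3 or with compound 1 and compound 2. Going by these compounds, the rest of the molecule is the same in all four, so it also remains open whether these small differences would persist on another core.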